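This account rests on a few compounds, and the source may have more. Where it says the series, first, only, none or still open, it means among the compounds named here.

Measured so far in a functional assay on PC-3 cells (Homo sapiens) for cytotoxicity, read by sulforhodamine B assay, with a stated time of 72 h; on this read-out higher numbers stand for weaker inhibition and lower numbers for stronger inhibition:
compound 1 `Nc1sc(-c2ccc(Cl)cc2)c(-c2ccc(Cl)cc2)c1C(=O)NC1CCCCC1` gives 7300 nM
compound 2 `Nc1sc(-c2ccc(Cl)cc2)c(-c2ccc(Cl)cc2)c1C(=O)Nc1ccccc1` gives only a limit, > 50000 nM
compound 3 `Nc1sc(-c2ccc(Cl)cc2)c(-c2ccc(Cl)cc2)c1C(=O)N1CCCC1` gives 6220 nM

Compound 2 stands at the limit of the assay, as marked by the limit of > 50000 nM in this assay, at which 1 of the 3 values shown sits; it sits apart from compound 1 by an at least 6.8-fold higher number from compound 1 to compound 2 (0.83 log units; beyond the scatter) and from compound 3 by an at least 8.0-fold lower number from compound 2 to compound 3 (0.90 log units; beyond the scatter), while compound 1 and compound 3 lie within a 1.2-fold lower number from compound 1 to compound 3 (0.07 log units; within the scatter) of each other. Compound 4 `COC(=O)c1c(N)sc(-c2ccc(Cl)cc2)c1-c1ccc(Cl)cc1` differs from compound 2 by methoxy in place of anilino on a carbonyl carbon. Among the measured compounds shown here, the steps that bear on this both lead away from the anilide: an at least 8.0-fold lower number from compound 2 to compound 3 (0.90 log units; beyond the scatter) and, in the reverse sense, an at least 6.8-fold higher number from compound 1 to compound 2 (0.83 log units; beyond the scatter). Methoxy likewise replaces anilino, so in this assay compound 4 is expected to move downward by an at least 5.0-fold lower number from compound 2 to compound 4 (0.69 log units; beyond the scatter). Compound 4 is therefore estimated at 10000 nM, with a range of 3000 nM to 40000 nM.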

Compound 4, half-maximal inhibitory concentration: 2780 nM
The estimate for compound 4 lay 3.6-fold (0.56 log units) above the measured number; measured number outside the range, below it.
By their numbers in this assay, from the lowest: compound 4; then compounds 3 and 1 (each within the scatter of the next). At a limit, above all of these: compound 2.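

Methoxy, which has no nitrogen and no ring, gives the lowest number so far at this carbonyl carbon in this assay, beyond the scatter from both compounds that had stood level: a 2.2-fold lower number from compound 3 to compound 4 (0.35 log units; beyond the scatter) and a 2.6-fold lower number from compound 1 to compound 4 (0.42 log units; beyond the scatter). The widest step at this place is an at least 17-fold lower number from compound 2 to compound 4 (1.25 log units; beyond the scatter), which can be read only as a bound. Compound 2 holds a limit and not a number: the limit of > 50000 nM in this assay, at which 1 of the 4 values shown sits.

The compounds shown leave open how a carboxylic acid, ethoxy or a longer alkoxy chain would behave at this carbonyl carbon. They also leave open whether a primary amide would sit with methoxy or with the amides.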